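The compounds below may be only part of what the source reports. "The series", "measured", "known", "first", "only" and "open" are said of these compounds alone.

Measured so far in a functional assay on BGC-823 cells (Homo sapiens) for cytotoxicity, read by MTT assay; a lower number here means a stronger inhibitor, a higher number a weaker inhibitor:
compound 1 `COc1cccc(/C=C/C(=O)c2sc(Nc3ccc(Cl)cc3)nc2C)c1` gives a limit, > 25000 nM.
compound 2 `COc1cccc(/C=C/C(=O)c2sc(Nc3ccccc3)nc2C)c1` gives 14300 nM.
compound 3 `Cc1nc(Nc2cccc(Cl)c2)sc1C(=O)/C=C/c1ccccc1` gives a limit, > 25000 nM.

Compound 2 and compound 3 differ in more than one place; the difference between the two cores is not broken down here. From compound 2 to compound 1 the change is chloro in place of hydrogen on an aromatic carbon, and it gives an at least 1.7-fold higher number from compound 2 to compound 1 (0.24 log units; that floor lies within the scatter), compound 1 sitting at the limit of > 25000 nM in this assay, at which 2 of the 3 values shown sit.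

Compound 4 `Cc1nc(Nc2ccc(Cl)c(Cl)c2)sc1C(=O)/C=C/c1ccccc1` is not yet measured. It differs from compound 3 by chloro in place of hydrogen on an aromatic carbon. The place is not identical to the earlier one: here the entering chloro is ortho to a chloro group as well as para to a large group, so this is the same kind of change, not the same. Compound 3 already sits at a limit in this assay. For compound 4 the expected step is a step that the limit leaves unreadable from compound 3 to compound 4. Compound 4 is therefore estimated at 40000 nM, most likely reported again as a limit, resting on compound 1 giving > 25000 nM after the same kind of change.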

Compound 4, half-maximal inhibitory concentration: 10600 nM
The estimate for compound 4 lay 3.8-fold (0.58 log units) above the measured number, and the stated range ends above it.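

In this assay, chloro in place of hydrogen on an aromatic carbon gives an at least 2.3-fold lower number from compound 3 to compound 4 (0.37 log units; beyond the scatter), so the change does not carry over in direction from one core to the other: the same change on two cores in this assay, an at least 1.7-fold higher number (0.24 log units; that floor lies within the scatter) from compound 2 to compound 1 and an at least 2.3-fold lower number (0.37 log units; beyond the scatter) from compound 3 to compound 4, at least 4.1-fold (0.61 log units) apart, beyond the scatter of two such steps

Both steps rest on a limit, so each gives only a floor and not a full size. The entering chloro is ortho to a chloro group only in compound 4 and the cores differ as well, so these two steps do not separate the two differences, and no general rule for this change follows.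

The compounds shown leave open how an amine or a carboxylic acid at the place of the entering chloro would read in this assay.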